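A hydroxy-to-carboxy swap on the shared core

A few compounds are considered here, and "the series" means these few. Any claim that something is new, unique, unknown or untested is made for them only; others in the source may bear on it.

Measured compounds:
Compound 1 `Cc1ccc2nc(C(=O)Nc3c(F)cc(-c4cccc(F)c4)cc3F)c(C)c(O)c2c1` gives 68.3% in a functional assay on Hep 3B2 cells (Homo sapiens) for antiproliferative activity, read by MTT assay, with a stated time of 24 h, tested at 100 ug/mL; a higher number here means a stronger effect of the compound at the concentration tested, a lower number a weaker effect
Compound 2 `CCOc1ccc2nc(C(=O)Nc3c(F)cc(-c4cccc(F)c4)cc3F)c(C)c(O)c2c1` gives 33.3% in this assay

Among the compounds with values here, compound 1 stands highest of the two numbers measured so far; its nearest neighbour is compound 2, and the single step known here, a number 35 percentage points lower from compound 1 to compound 2 (beyond the scatter), came from putting ethoxy in place of methyl on an aromatic carbon, a change beyond the scatter.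

Compound 3 `Cc1ccc2nc(C(=O)Nc3c(F)cc(-c4cccc(F)c4)cc3F)c(C)c(C(=O)O)c2c1` is not yet measured. It differs from compound 1 in this way: carboxy in place of hydroxy on an aromatic carbon. Within the data shown here, no measured step touches this part of the shared core; the one step known, ethoxy in place of methyl on an aromatic carbon, sits elsewhere and concerns a different pair of groups, so it does not bear on the hydroxy-to-carboxy change. The expectation for compound 3 therefore rests on compound 1 alone, with wide uncertainty. Compound 3 is expected to give 45%, within a range from 15% to 75%. This estimate means an expected step of a number 23.3 percentage points lower from compound 1 to compound 3 (beyond the scatter), a moderate fall, though a result within the scatter of compound 1 would not surprise.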

Compound 3, a percentage reported as inhibition, at one concentration (the size of the read-out at that concentration, not a potency): 75.2%
Estimate against measurement, compound 3: 30.2 percentage points below; measured number outside the range, above it.
By their numbers in this assay, from the lowest: compound 2; then compounds 1 and 3 (each within the scatter of the next).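

A step of a number 6.9 percentage points higher from compound 1 to compound 3 (within the scatter) in this assay shows that, at this position opposite the ring nitrogen and ortho to a methyl group, carboxy can stand in place of hydroxy without a difference that this assay can separate from the scatter. The entering group brings 3 heavy atoms where the leaving group had 1, and it adds 1 double bond outside aromatic rings, yet compound 1 and compound 3 cannot be told apart here, whereas the other change on compound 1 gave a clear fall of a number 35 percentage points lower from compound 1 to compound 2 (beyond the scatter) in the same read-out. No measurement at hand explains why this position accepts the swap while the ethoxy change does not leave the number in place.

The compounds shown leave open how an amine, a methoxy group or a plain hydrogen would read at this position, and so whether the hydroxy and carboxy results reflect a general tolerance there or something the two groups share. They also leave open whether carboxy at this position would give the same reading alongside the ethoxy group of compound 2.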